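This account rests on a few compounds, and the source may have more. Where it says the series, first, only, none or still open, it means among the compounds named here.

The study concerns antiproliferative activity measured in a functional assay on CFPAC-1 cells (Homo sapiens) for antiproliferative activity, read by MTT assay, with a stated time of 72 h; a lower number here means a stronger inhibitor, a higher number a weaker inhibitor. Compound 1 `Cc1ccc(S(=O)(=O)NCc2cn(C[C@H](O)[C@H]3OC(=O)C(OCc4ccccc4)=C3OCc3ccccc3)nn2)cc1` gives 68000 nM in this assay. Compound 2 `COc1ccc(-c2cn(C[C@H](O)[C@H]3OC(=O)C(OCc4ccccc4)=C3OCc3ccccc3)nn2)cc1` gives 26000 nM, and the change between them reads a 2.6-fold lower number from compound 1 to compound 2 (0.42 log units; beyond the scatter). Compound 3 `O=C1O[C@H]([C@@H](O)Cn2cc(CCO)nn2)C(OCc2ccccc2)=C1OCc1ccccc1` returns only a limit of the assay, > 100000 nM. Set against compound 1 this appears as an at least 1.4-fold higher number from compound 1 to compound 3 (0.16 log units; that floor lies within the scatter), and against compound 2 as an at least 3.8-fold higher number from compound 2 to compound 3 (0.58 log units; beyond the scatter). Compound 3 therefore stands at the weak edge of what has been measured, without a number of its own, as recorded by the limit of > 100000 nM in this assay, at which 1 of the 3 values shown sits.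

The next compound, compound 4 `O=C1O[C@H]([C@@H](O)Cn2cc(CNS(=O)(=O)c3ccc(Cl)cc3)nn2)C(OCc2ccccc2)=C1OCc1ccccc1`, has not yet been measured. It differs from compound 3 in one place: ((4-chlorophenyl)sulfonyl)amino in place of hydroxymethyl on a saturated chain carbon bound to an aromatic carbon. Going by the values given here, the step that bears on it is the one between compound 1 and compound 3, which runs the other way across a closely similar change and measured an at least 1.4-fold higher number from compound 1 to compound 3 (0.16 log units; that floor lies within the scatter); reversing it should bring the number back toward the region of compound 1. Compound 4 is therefore expected to show an at least 1.4-fold lower number from compound 3 to compound 4 (0.15 log units; that floor lies within the scatter) in this assay, with an estimated value of 70000 nM and a range from 35000 nM to 150000 nM.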

Compound 4, half-maximal inhibitory concentration: 38900 nM
Beside the measured number, compound 4's estimate is 1.8-fold (0.26 log units) above it; the measured number falls inside the stated range.
By their numbers in this assay, from the lowest: compounds 2, 4 and 1 (each within the scatter of the next, the first and the last beyond it). At a limit, above all of these: compound 3.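

In this assay putting ((4-chlorophenyl)sulfonyl)amino in place of hydroxymethyl on a saturated chain carbon bound to an aromatic carbon gives an at least 2.5-fold lower number from compound 3 to compound 4 (0.41 log units; beyond the scatter) and so reads beyond the scatter, which the floor in an at least 1.4-fold higher number from compound 1 to compound 3 (0.16 log units; that floor lies within the scatter) could not show. Chloro in place of methyl on an aromatic carbon gives a 1.7-fold lower number from compound 1 to compound 4 (0.24 log units; within the scatter) and leaves compound 1 and compound 4 unseparated. The comparison with the aryl-bearing compound gives a 1.5-fold higher number from compound 2 to compound 4 (0.17 log units; within the scatter), so (((4-chlorophenyl)sulfonyl)amino)methyl and 4-methoxyphenyl on an aromatic carbon cannot be told apart here.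

As far as these compounds go, compound 3 remains a limit of the assay, so the full size of its step stays open: the limit of > 100000 nM in this assay, at which 1 of the 4 values shown sits. From the compounds shown here alone, whether an amine or a carboxylic acid on that saturated chain carbon would also lower the number remains open.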